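Replacing the phenyl of compound 2

A few compounds are considered here, and "the series" means these few. Any claim that something is new, unique, unknown or untested is made for them only; others in the source may bear on it.

Measured in an ADME assay on ECV-304 cells (Homo sapiens) for cytotoxicity, read by MTT assay, with a stated time of 72 h; on this read-out lower numbers stand for stronger inhibition and higher numbers for weaker inhibition:
- compound 1 `COc1ccc(OC)c(C2=C(c3cc(OC)c(OC)c(OC)c3)C(=O)CC2O[SiH2]C(C)(C)C)c1`: 6.5 ug/mL
- compound 2 `COc1cc(C2=C(c3ccccc3)C(O[SiH2]C(C)(C)C)CC2=O)cc(OC)c1OC`: > 100 ug/mL (a limit)

In this assay compound 2 gives > 100 ug/mL, which is a limit and not a number.

Compound 3 `COCOc1cc(C2=C(c3cc(OC)c(OC)c(OC)c3)C(=O)CC2O[SiH2]C(C)(C)C)ccc1OC` is next, with 4-methoxy-3-(methoxymethoxy)phenyl in place of phenyl on a double-bonded ring carbon.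

Among the compounds with values here, one measured step bears on this change. It is an at least 15-fold higher number from compound 1 to compound 2 (1.18 log units; beyond the scatter), a large step beyond the scatter, in which phenyl took the place of 2,5-dimethoxyphenyl on a double-bonded ring carbon. The new change runs the opposite way, from phenyl to a substituted phenyl, although the entering group is a different one. A large step to a lower number is therefore expected in this assay, on this single precedent. The expected step is an at least 8.3-fold lower number from compound 2 to compound 3 (0.92 log units; beyond the scatter). For compound 3 the estimated value is 12 ug/mL, with an expected range of 3 ug/mL to 60 ug/mL.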

Compound 3, half-maximal inhibitory concentration: 40 ug/mL
Compound 3: the middle estimate sits 3.3-fold (0.52 log units) below what was measured; the range from low to high includes it.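

In this assay, a substituted phenyl on this double-bonded ring carbon brings a measured number in place of a limit: an at least 2.5-fold lower number from compound 2 to compound 3 (0.39 log units; beyond the scatter). The recovery is therefore not confined to 2,5-dimethoxyphenyl, but 4-methoxy-3-(methoxymethoxy)phenyl does not match that group, as the comparison with the more active compound shows: a 6.2-fold higher number from compound 1 to compound 3 (0.79 log units; beyond the scatter). The first of these steps has only a lower bound, since compound 2 stands at a limit and not at a number: the limit of > 100 ug/mL in this assay, at which 1 of the 3 values shown sits.

The compounds shown do not separate the part played by the methoxy from that of the methoxymethoxy, since the two substituted phenyls differ in both groups and in how they are arranged. Going by these compounds, whether a hydroxyl in place of the methoxymethoxy, or an amine or a chlorine on this phenyl, would come closer to compound 1 remains open.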